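The source may hold more compounds than are shown below. What is called first, only, known or untested is meant among the compounds shown, and "the series" means these compounds.

Compound 1 `Clc1ccc(-c2n[nH]cc2N2CCCNCC2)cc1` gives 1230 nM in an assay on isolated protein for binding affinity to 5-hydroxytryptamine receptor 1D (Homo sapiens); on this read-out lower numbers stand for stronger inhibition and higher numbers for weaker inhibition. Compound 2 `Fc1ccc(-c2n[nH]cc2N2CCCNCC2)cc1` carries fluoro in place of chloro on an aromatic carbon and gives 2190 nM in this assay, so the step of a 1.8-fold higher number from compound 1 to compound 2 (0.25 log units; within the scatter). Compound 3 `Clc1ccc(-c2n[nH]cc2N2CCNCC2)cc1` is a different core; how it differs from compound 1 is not broken down here. In this assay compound 3 reaches only the limit > 10000 nM, which is a limit of the assay and not a number (the limit of > 10000 nM in this assay, at which 1 of the 3 values shown sits). Compound 4 `Fc1ccc(-c2n[nH]cc2N2CCNCC2)cc1` carries fluoro in place of chloro on an aromatic carbon, the same change as from compound 1 to compound 2, at a place described in the same words. Beside the measured step from compound 1 to compound 2, the step that the limit leaves unreadable from compound 3 to compound 4 is expected to be small, resting on compound 1 and compound 2 sitting within the scatter. Compound 4 is therefore estimated at 18000 nM in this assay, most likely again reported only as a limit.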

Compound 4, inhibition constant: > 10000 nM
Compound 4: only a limit was reported; the forecaster's own chance of this, stated with the estimate: 80%; the middle value lies beyond the limit too.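

Within the data shown here, compound 3 and compound 4 both stop at a limit in this assay, not at a number, so no step between them can be read: the limit of > 10000 nM in this assay, at which 2 of the 4 values shown sit. Going by these compounds, whether fluoro in place of chloro changes the read-out on the core of compound 3 stays open.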